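The source may report more compounds than this note shows. Statements on the series, on what has been measured and on what is new or still open speak of the compounds shown alone.

Compound 1 `CCOC(=O)c1c(-c2cccc(-c3ccccc3)c2)[nH]c2cc(OC)ccc2c1=O`, compound 2 `CCOC(=O)c1c(-c2cccc(OC)c2)[nH]c2cc(OC)ccc2c1=O` and compound 3 `CCOC(=O)c1c(-c2cccc(-c3ccccc3)c2)[nH]c2cc(OC)c(OC)cc2c1=O` share a core and have all been tested in an ADME assay on HEK293 cells (Homo sapiens) for cytotoxicity, read by luminescence, with a stated time of 72 h; on this read-out higher numbers stand for an effect only at larger amounts of compound and lower numbers for an effect already at smaller amounts. Compound 1 gives > 22000 nM, which is a limit of the assay and not a number. Compound 2 gives > 22000 nM, which is also a limit. Compound 3 gives > 22000 nM, again a limit, so compound 3 has no exact number of its own. Among the compounds with values here, the whole series so far is summed up as the limit of > 22000 nM in this assay, at which 3 of the 3 values shown sit.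

Compound 4 `CCOC(=O)c1c(-c2cccc(OC)c2)[nH]c2cc(OC)c(OC)cc2c1=O` differs from compound 3 in one place: methoxy in place of phenyl on an aromatic carbon. Methoxy replaces phenyl on an aromatic carbon, meta to a large group. The closest guide is the same exchange in another pair, a step that the two limits leave unreadable from compound 1 to compound 2. The other measured change, methoxy in place of hydrogen on an aromatic carbon, is a step that the two limits leave unreadable from compound 1 to compound 3. Within the data shown here, neither step has a readable size, but every compound measured so far sits at the limit. No step beyond the usual scatter is therefore expected in this assay, and no direction can be predicted. The expected change is a step that the limit leaves unreadable from compound 3 to compound 4, and the assay will most likely report only a limit again. For compound 4 the estimate is 30000 nM, with an expected range from 15000 nM to 60000 nM.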

Compound 4, half-maximal effective concentration: > 22000 nM
Compound 4: only a limit was reported (the forecaster's own chance of this, stated with the estimate: 90%); the middle value lies beyond the limit too.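

No step can be read from compound 3 to compound 4 or from compound 2 to compound 4: in this assay each of these compounds gives only a limit, not a number. The compounds shown leave open whether exchanging phenyl for methoxy, or adding a methoxy, changes the result in this assay at all, and the series stands as follows: the limit of > 22000 nM in this assay, at which 4 of the 4 values shown sit.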